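The compounds below may be only part of what the source reports. "The series", "measured", "known", "first", "only" and "open" are said of these compounds alone.

Measured compounds in a toxicity assay on NIH3T3 cells (Mus musculus) for cytotoxicity, read by resazurin assay; a higher number here means that more compound is needed for the effect, a lower number that less compound is needed:
Compound 1 `CN(C)c1ccc(NCc2cncn2Cc2ccc(-c3ccccc3)cc2)cc1-c1ccccc1` gives only a limit, > 1000 nM.
Compound 2 `Cc1ccccc1-c1cccc(NCc2cncn2Cc2ccccc2)c1` gives only a limit, > 1000 nM.
Compound 3 `Cc1cccc(-c2cccc(NCc3cncn3Cc3ccccc3)c2)c1` gives only a limit, > 1000 nM.

Compound 1 thus stands at a limit rather than at a number, and the two further values shown are limits as well, so all three rest together at the limit of > 1000 nM in this assay, at which 3 of the 3 values shown sit. The change to compound 4 `c1ccc(-c2ccc(Cn3cncc3CNc3ccc(-c4cc5ccccc5o4)c(-c4ccccc4)c3)cc2)cc1` is 1-benzofuran-2-yl in place of dimethylamino on an aromatic carbon. Going by the values given here, the only measured step, a step that the two limits leave unreadable from compound 2 to compound 3, cannot be read from its two limits, so no measured step tells how large a change of this kind can be, and no direction beyond the scatter is foreseen. Compound 4 is expected to stay near this same limit, at an estimated 1500 nM with a range from 500 nM to 5000 nM. This amounts to an expected step that the limit leaves unreadable from compound 1 to compound 4.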

Compound 4, half-maximal effective concentration: > 10000 nM
Compound 4 ended at the assay's limit (the forecaster's own chance of this, stated with the estimate: 60%); at least 6.6-fold (0.82 log units) between middle value and limit.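

Compound 1 and compound 4 both give only limits, not numbers, so the change between them cannot be read. The compounds shown leave open what concentration of any of them would produce the effect in this assay.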